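The source may report more compounds than this note shows. Statements on the series, on what has been measured and on what is new or still open speak of the compounds shown alone.

Measured in a functional assay on KB 3-1 cells (Homo sapiens) for cytotoxicity, read by MTT assay, with a stated time of 72 h; a lower number here means a stronger inhibitor, a higher number a weaker inhibitor:
- Compound 1 `O=C1Nc2ccccc2/C1=N/NC(=S)Nc1cccc2ccccc12`: 5120 nM
- Compound 2 `O=C1Nc2ccccc2/C1=N/NC(=S)Nc1ccc(C(=O)O)cc1`: > 50000 nM

Compound 2 gives no exact number, since its > 50000 nM is only a limit of the assay. Compound 3 `CC(C)(C)c1ccc(NC(=S)N/N=C2\C(=O)Nc3ccccc32)cc1` has not yet been measured. It has tert-butyl in place of carboxy on an aromatic carbon, para to a large group: tert-butyl in place of carboxy on an aromatic carbon.

Among the compounds with values here, no pair of measured compounds differs in one place alone, so no measured step can serve as a guide. Within the data shown here, the only other reference is compound 1, which also lacks the carboxy and gives 5120 nM. On that basis, compound 3 is expected to land near compound 1, with a clearly lower number in this assay, meaning a stronger inhibitor. The expected change is an at least 12-fold lower number from compound 2 to compound 3 (1.09 log units; beyond the scatter). For compound 3 the estimated value is 4000 nM, with an expected range from 1200 nM to 15000 nM.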

Compound 3, half-maximal inhibitory concentration: 8130 nM
Beside the measured number, compound 3's estimate is 2.0-fold (0.31 log units) below it, within the range that was stated.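

Putting tert-butyl in place of carboxy on this aromatic carbon, para to a large group, gives the first single-change comparison among these compounds in this assay, and the result is an at least 6.1-fold lower number from compound 2 to compound 3 (0.78 log units; beyond the scatter). The position therefore responds to this change: carboxy, with its hydrogen-bond donor and acceptor, gives way to an all-carbon group with neither, and the number falls beyond the usual scatter. From the compounds shown here alone, the true size of the step stays unknown because compound 2 stands at a limit of the assay, not at an exact number: the limit of > 50000 nM in this assay, at which 1 of the 3 values shown sits.

These compounds cannot separate the effect of losing carboxy from that of gaining tert-butyl. A plain hydrogen, a methyl group or an amine at the same position would help to tell those two effects apart.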